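From ethoxycarbonyl to carbamoyl at the assay limit

The compounds below may be only part of what the source reports. "The series", "measured", "known", "first", "only" and "open" are said of these compounds alone.

In a functional assay on HeLa cells (Homo sapiens) (on this read-out lower numbers stand for an effect already at smaller amounts and higher numbers for an effect only at larger amounts of compound), compound 1 (`CCOC(=O)c1cc(CI)[nH]n1`) gives > 100 ug/mL, which is a limit of the assay and not a number. Compound 2 (`CCOC(=O)c1cc(CCl)nn1C1O[C@H](COC(C)=O)[C@@H](OC(C)=O)[C@H](OC(C)=O)[C@H]1OC(C)=O`) gives > 100 ug/mL, again only a limit. The whole picture so far is the limit of > 100 ug/mL in this assay, at which 2 of the 2 values shown sit. Compound 3 (`CC(=O)OC[C@H]1OC(n2nc(CCl)cc2C(N)=O)[C@H](OC(C)=O)[C@@H](OC(C)=O)[C@@H]1OC(C)=O`) carries amino in place of ethoxy on a carbonyl carbon, ethoxycarbonyl to carbamoyl (amino in place of ethoxy on a carbonyl carbon). Within the data shown here, no measured step shows what this change does, so no shift beyond the usual scatter is expected, and the expected move is a number no higher from compound 2 to compound 3 (the limit leaves the size open). Compound 3 is estimated at 100 ug/mL, with an expected range of 40 ug/mL to 200 ug/mL.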

Compound 3, concentration for half-maximal effect: 12 ug/mL
The estimate for compound 3 lay 8.3-fold (0.92 log units) above the measured number, outside the stated range (below it).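

Among these compounds, the change from ethoxycarbonyl to carbamoyl gives the first value in this assay that is a number and not a limit, with an at least 8.3-fold lower number from compound 2 to compound 3 (0.92 log units; beyond the scatter). Going by these compounds, the true size of this step stays open because compound 2 holds only a limit: the limit of > 100 ug/mL in this assay, at which 2 of the 3 values shown sit.

On these data alone, whether a carboxylic acid or a methylamide at this carbonyl carbon would keep the lower number remains open. Among the compounds shown here, also open is whether the same change would act alike on the core of compound 1, since only one pair shows it.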